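The compounds below may be only part of what the source reports. "The series", "measured", "known", "first", "only" and "open" are said of these compounds alone.

Series notes. Compound 1 `CC(C)(C)c1csc(N)c1C(=O)c1ccc(Cl)cc1`, compound 2 `CC(C)(C)Cc1c(-c2cccnc2)sc(N)c1C(=O)c1ccc(Cl)cc1` and compound 3 `CC(C)(C)Cc1c(-c2cc(F)ccc2F)sc(N)c1C(=O)c1ccc(Cl)cc1` share one core and differ only at the ring carbon next to the sulfur. In an assay on CHO cells for displacement of a labelled ligand from adenosine receptor A3 (Homo sapiens), read by scintillation counting, tested at 10 uM (a higher number here means more inhibition at the concentration tested (going by the name of the read-out), a lower number less inhibition), compound 1 gives 1%, compound 2 gives 1% and compound 3 gives 1%, so compound 3 stands level with both at the digits shown. Among the measured compounds shown here, the single one-place step measured, no change at the digits printed from compound 2 to compound 3 (within the scatter), lies within the scatter. Compound 4 `CC(C)(C)Cc1c(Br)sc(N)c1C(=O)c1ccc(Cl)cc1` differs from compound 3 by bromo in place of 2,5-difluorophenyl on an aromatic carbon. For the measured compounds named here, no measured step swaps an aromatic ring for bromo at this position, so nothing here points to movement beyond the scatter. For compound 4 the step is expected to be a number 1 percentage points higher from compound 3 to compound 4 (within the scatter). Compound 4 is therefore estimated at 2% in this assay, with a range of 0% to 12%.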

Compound 4, a percentage reported as inhibition, at one concentration (the size of the read-out at that concentration, not a potency): 1%
Estimate against measurement, compound 4: 1 percentage points above; the range from low to high includes it.
By their numbers in this assay, from the lowest: compounds 1, 2, 3 and 4 (each within the scatter of the next).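

At the ring carbon next to the ring sulfur, bromo in place of 2,5-difluorophenyl gives no change at the digits printed from compound 3 to compound 4 (within the scatter) in this assay, and bromo in place of pyridin-3-yl gives no change at the digits printed from compound 2 to compound 4 (within the scatter). The earlier step compared two aromatic rings only; this position now also takes a group with no ring and the read-out stays level. Nothing measured here speaks to why.

As far as these compounds go, whether any group at this carbon can lift the read-out on the shared core stays open. A carboxylic acid or an amine here could still behave differently.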